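This account rests on a few compounds, and the source may have more. Where it says the series, first, only, none or still open, it means among the compounds named here.

Compound 2 `CC1(C)CC(=O)C=C(Nc2ccc(Cl)cc2)C1` is the reference here. In a functional assay on cells (blood, Homo sapiens) for inhibition, read by chemiluminescence, with a stated time of 30 min (a lower number here means a stronger inhibitor, a higher number a weaker inhibitor), compound 2 reaches only the limit of > 100 ug/mL, which is not a number. Compound 1 `CC1(C)CC(=O)C=C(Nc2ccc(Cl)cc2Cl)C1` likewise gives only the limit > 100 ug/mL. Compound 3 `CCCCSC(=S)C1=C(Nc2ccc(Cl)cc2)CC(C)(C)CC1=O` also stops at the limit > 100 ug/mL. The two measured steps that touch compound 2, a step that the two limits leave unreadable from compound 1 to compound 2 and a step that the two limits leave unreadable from compound 2 to compound 3, therefore have no readable size, because of the limit of > 100 ug/mL in this assay, at which 3 of the 3 values shown sit. Compound 4 `CC1(C)CC(=O)C=C(Nc2ccc(Br)cc2)C1` differs from compound 2 by bromo in place of chloro on an aromatic carbon. Among the compounds with values here, with every neighbour sitting at the same limit, no measured step bears on this change, and neither a size nor a direction can be read from it. Compound 4 is therefore expected to give about 100 ug/mL in this assay, between 30 ug/mL and 300 ug/mL. The expected step of a number no higher from compound 2 to compound 4 (the limit leaves the size open) is an estimate resting on the limits alone.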

Compound 4, half-maximal inhibitory concentration: > 100 ug/mL
Compound 4 gave a limit, no number; the forecaster's own chance of this, stated with the estimate: 80%; the middle value lies on the limit itself.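

No new step can be read between compound 2 and compound 4, because both stop at a limit, which is not a number: the limit of > 100 ug/mL in this assay, at which 4 of the 4 values shown sit.

The compounds shown leave open how strongly any of them inhibits in this assay, and whether bromo and chloro differ there at all.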